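Quinone amine series: cyclohexyl amine to 2-fluorophenyl amine

The source may report more compounds than this note shows. Statements on the series, on what has been measured and on what is new or still open speak of the compounds shown alone.

Compound 1, `O=C1C(NC2CC2)=CC(=O)c2c1nc1n2[C@H]2OC[C@@H](O)[C@H]2OC1`, in a functional assay on HeLa cells (Homo sapiens) for inhibition, read by sulforhodamine B assay (on this read-out higher numbers stand for weaker inhibition and lower numbers for stronger inhibition), gives > 16000 nM, a limit of the assay and not a number.
Compound 2, `O=C1C=C(NC2CCCC2)C(=O)c2c1nc1n2[C@H]2OC[C@@H](O)[C@H]2OC1`, in this assay gives > 16000 nM, again a limit.
Compound 3, `O=C1C=C(NC2CCCCC2)C(=O)c2c1nc1n2[C@H]2OC[C@@H](O)[C@H]2OC1`, in this assay gives > 16000 nM, also a limit.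

Compound 3 therefore stands at the limit of this assay with no number of its own; every value shown sits at that same limit (the limit of > 16000 nM in this assay, at which 3 of the 3 values shown sit). For the measured compounds named here, the only one-place step among the measured compounds, a step that the two limits leave unreadable from compound 2 to compound 3, rests on two limits and carries no readable size or direction.

Compound 4, `O=C1C=C(Nc2ccccc2F)C(=O)c2c1nc1n2[C@H]2OC[C@@H](O)[C@H]2OC1`, differs from compound 3 in one place: 2-fluorophenyl in place of cyclohexyl on an amine nitrogen. Going by the values given here, no measured step swaps a saturated ring for an aromatic one on the amine nitrogen, so the measured material gives nothing to read for this change beyond the fact that the cyclopropyl, cyclopentyl and cyclohexyl amines all remain at the limit.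

The estimate for compound 4 in this assay is 20000 nM, with an expected range from 5000 nM to 80000 nM. For compound 4 the expected step that the limit leaves unreadable from compound 3 to compound 4 means no shift beyond the scatter is expected, and a value at or near the limit is the most likely report, with a fair chance of a limit only.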

Compound 4, half-maximal inhibitory concentration: 5120 nM
The estimate for compound 4 lay 3.9-fold (0.59 log units) above the measured number; the measured number falls inside the stated range.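

The amine nitrogen can move the read-out in this assay: 2-fluorophenyl in place of cyclohexyl gives an at least 3.1-fold lower number from compound 3 to compound 4 (0.49 log units; beyond the scatter), and 2-fluorophenyl in place of cyclopentyl gives an at least 3.1-fold lower number from compound 2 to compound 4 (0.49 log units; beyond the scatter). From the compounds shown here alone, compound 3 gives > 16000 nM, a limit and not a number, and the true size of both steps stays open, as each is a minimum only. Compound 4 is the only one of the compounds shown to give a number rather than a limit, so this aromatic ring on the amine nitrogen is the first change here with a readable direction: the limit of > 16000 nM in this assay, at which 3 of the 4 values shown sit.

Going by these compounds, whether the lower number goes with the aromatic ring itself or with the fluorine stays open, and plain phenyl on the same amine nitrogen would separate the two. On these data alone, how far the trend extends is also open, since a benzyl or pyridyl group on this nitrogen could show whether the step depends on a carbon-only aromatic ring bound directly to the nitrogen.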